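The compounds below may be only part of what the source reports. "The series", "measured", "known", "first", "only" and "open" are said of these compounds alone.

Measured so far in an ADME assay on the whole organism (plasma) for pharmacokinetics, with Rhesus monkey (Macaca mulatta) as the target, read by LC-MS, at a dose of 1 mg/kg by the oral route; on this read-out lower numbers stand for lower exposure and higher numbers for higher exposure at the dose given:
Compound 1 `COc1ccc2nc(COc3ccc(CC4(O)SC(=O)NC4=O)cc3)n(C)c2c1` gives 7.33 ng.h/mL
Compound 2 `COc1ccc2nc(COc3ccc(CC(SC(=O)N[C@@H]4O[C@H](C(=O)O)[C@@H](O)[C@H](O)[C@H]4O)C(=O)O)cc3)n(C)c2c1` gives 673 ng.h/mL
Compound 3 `COc1ccc2nc(COc3ccc(CC(SSCC(N)C(=O)O)C(=O)O)cc3)n(C)c2c1` gives 12.3 ng.h/mL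

Compound 1 and compound 3 lie together at the low end, within the scatter of each other, while compound 2 lies far beyond the scatter above them. Among the measured compounds shown here, compound 4 `COc1ccc2nc(COc3ccc(CC(C(N)=O)S(C)(=O)=O)cc3)n(C)c2c1` carries carbamoyl(methylsulfonyl)methyl in place of 5-hydroxy-2,4-dioxo-1,3-thiazolidin-5-yl on a saturated chain carbon bound to an aromatic carbon as its only difference from compound 1. For the measured compounds named here, no measured step isolates this change. A small rise in this assay is expected, with a 2.7-fold higher number from compound 1 to compound 4 (0.44 log units; beyond the scatter) as the estimated step. That expectation leans on compound 1 at 7.33 ng.h/mL and compound 3 at 12.3 ng.h/mL while compound 2 at 673 ng.h/mL keeps the upper end open. For compound 4 the estimated value is 20 ng.h/mL with an expected range from 5 ng.h/mL to 120 ng.h/mL in this assay.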

Compound 4, area under the concentration-time curve: 27 ng.h/mL
Beside the measured number, compound 4's estimate is 1.4-fold (0.13 log units) below it; the measured number falls inside the stated range.
By their numbers in this assay, from the lowest: compounds 1 and 3 (each within the scatter of the next); then compound 4; then compound 2.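

Replacing 5-hydroxy-2,4-dioxo-1,3-thiazolidin-5-yl with carbamoyl(methylsulfonyl)methyl on a saturated chain carbon bound to an aromatic carbon gives, in this assay, a 3.7-fold higher number from compound 1 to compound 4 (0.57 log units; beyond the scatter). Among the compounds shown here, this is the first single-place step at this position, and it shows that exposure here can rise modestly when the ring gives way to an open group with the same count of heavy atoms. Nothing available explains the rise. As far as these compounds go, it remains open whether a carboxylic acid or an amine in place of the carbamoyl would move the number further, and which of the two groups on the new carbon, carbamoyl or methylsulfonyl, carries the step.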